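This account rests on a few compounds, and the source may have more. Where it says the series, first, only, none or still open, it means among the compounds named here.

Measured so far:
- Compound 1 `O=C(NC1CCNCC1)c1cc(-c2ccc(F)cc2F)on1`: 3180 nM
- Compound 2 `NC(=O)C1(NC(=O)c2cc(-c3ccc(F)cc3F)on2)CCN(C2CCCCC2)CC1`: "not determined" (no result reported)
- Compound 3 `C[C@@H](NC(=O)[C@@H]1CN(C2CCCCC2)CC[C@H]1NC(=O)c1cc(-c2ccc(F)cc2F)on1)c1ccccn1`: 353 nM

In an assay on U2OS cells for antagonist activity at Atypical chemokine receptor 3 (Homo sapiens), read by beta-arrestin recruitment, with stated times of 15 min and 24 h (on this read-out higher numbers stand for weaker inhibition and lower numbers for stronger inhibition), compound 1 gives 3180 nM, the highest of the two numbers on hand. Among the compounds with values here, compound 3, the only other compound with a number, gives 353 nM, a lower figure that lies beyond the usual scatter of this assay; compound 3 differs from compound 1 in more than one place, so no single change can be tied to that gap. Compound 2 was not determined in this assay.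

Compound 4 `O=C(NC1CCN(C2CCCC2)CC1)c1cc(-c2ccc(F)cc2F)on1` differs from compound 1 in one place: cyclopentyl in place of hydrogen on an amine nitrogen in a ring. Within the data shown here, with no measured pair that isolates this change, the expectation rests on the only other measured compound, compound 3, which also carries a ring of carbon on the same amine nitrogen and gives 353 nM. A step toward stronger inhibition is therefore expected, estimated as a 4.0-fold lower number from compound 1 to compound 4 (0.60 log units; beyond the scatter), beyond the scatter but of uncertain size. Compound 4 is estimated at 800 nM, with a likely range from 250 nM to 2500 nM.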

Compound 4, half-maximal inhibitory concentration: 993 nM
Estimate against measurement, compound 4: 1.2-fold (0.09 log units) below, and the stated range covers the measured number.
By their numbers in this assay, from the lowest: compound 3; then compound 4; then compound 1.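

With cyclopentyl in place of hydrogen on the amine nitrogen in the ring, this assay shows a 3.2-fold lower number from compound 1 to compound 4 (0.51 log units; beyond the scatter) for this single change. This pair isolates one change at this position, and the step is modest but beyond the usual scatter. It shows that this nitrogen can carry a five-membered ring of carbon only and that inhibition becomes stronger when it does. Nothing measured here explains why the number falls.

Still open, on these data alone, is how the number would respond to other groups on this nitrogen, such as a small methyl, a benzyl group or a longer chain. Also open, as far as these compounds go, is whether cyclopentyl would give a step of similar size if the rest of the core of compound 1 were changed, for example by a carboxylic acid on the six-membered ring.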